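This account rests on a few compounds, and the source may have more. Where it says the series, first, only, none or still open, it means among the compounds named here.

In a functional assay on MCF7 cells (Homo sapiens) for inhibition, read by MTT assay, with a stated time of 72 h (on this read-out higher numbers stand for weaker inhibition and lower numbers for stronger inhibition), compound 1 `COc1cc2c(Oc3ccc(NC(=O)c4nn(-c5ccccc5C)cc(C)c4=O)cc3)ccnc2cc1OCCCCCC(=O)NO` gives 1830 nM. Compound 2 `COc1cc2c(Oc3ccc(NC(=O)c4nn(-c5ccccc5C)ccc4=O)cc3)ccnc2cc1OCCCCCC(=O)NO` gives 4360 nM in this assay, so a 2.4-fold higher number from compound 1 to compound 2 (0.38 log units; beyond the scatter), the change being (hydrogen in place of methyl on an aromatic carbon). Compound 3 `COc1cc2c(Oc3ccc(NC(=O)c4nn(-c5ccccc5C)cc(C)c4=O)cc3)ccnc2cc1OCCCCCCC(=O)NO` gives 1830 nM; its core differs from that of compound 1 by (hydroxycarbamoyl)methyl in place of hydroxycarbamoyl on a saturated chain carbon, five bonds along the chain from an oxygen on an aromatic ring, and no change at the digits printed from compound 1 to compound 3 (within the scatter). Compound 4 `COc1cc2c(Oc3ccc(NC(=O)c4nn(-c5ccccc5)cc(C)c4=O)cc3)ccnc2cc1OCCCCCCC(=O)NO` awaits measurement in this assay; it differs from compound 3 by hydrogen in place of methyl on an aromatic carbon. This is the same kind of change as from compound 1 to compound 2, not the same: there the methyl sat on a six-membered aromatic ring with 2 nitrogen, two atoms from the ring nitrogen and meta to a 2-methylphenyl group, whereas here it sits on a six-membered aromatic ring of carbon only, ortho to a large group. Because the earlier step was a 2.4-fold higher number from compound 1 to compound 2 (0.38 log units; beyond the scatter), compound 4 is expected to show a somewhat higher number than compound 3, estimated as a 1.5-fold higher number from compound 3 to compound 4 (0.18 log units; within the scatter). Compound 4 is expected at about 2800 nM, between 1200 nM and 6500 nM.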

Compound 4, half-maximal inhibitory concentration: 1610 nM
Beside the measured number, compound 4's estimate is 1.7-fold (0.24 log units) above it, and the stated range covers the measured number.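

In this assay, going from 2-methylphenyl to phenyl gives a 1.1-fold lower number from compound 3 to compound 4 (0.06 log units; within the scatter), so on the core of compound 3 this replacement of methyl by hydrogen shows no effect beyond the scatter. Hydrogen in place of methyl on an aromatic carbon therefore does not carry over as one fixed step in this series: the same change on two cores in this assay, a 2.4-fold higher number (0.38 log units; beyond the scatter) from compound 1 to compound 2 and a 1.1-fold lower number (0.06 log units; within the scatter) from compound 3 to compound 4, 2.7-fold (0.43 log units) apart, beyond the scatter of two such steps. This does not show why the steps differ: the methyl stands on a different ring in each pair and the chains also differ, so these two steps cannot separate those differences.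

The compounds shown leave open how an ethyl group or a chlorine in place of that methyl would read. They also leave open whether a shorter chain would alter either step.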